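Dihydropyrimidinone esters: aryl substitution and the functional read-out

The source may report more compounds than this note shows. Statements on the series, on what has been measured and on what is new or still open speak of the compounds shown alone.

Measured so far:
compound 1 `CCOC(=O)C1=C(C)NC(=O)NC1c1ccc(O)cc1`: 0.89 ug/mL
compound 2 `COC(=O)C1=C(C)NC(=O)NC1c1ccccc1`: 2.23 ug/mL

In a functional assay, read by spectrophotometry, with a stated time of 10 min (on this read-out lower numbers stand for an effect already at smaller amounts and higher numbers for an effect only at larger amounts of compound), compound 2 gives 2.23 ug/mL, the highest of the two numbers recorded; compound 1 gives 0.89 ug/mL, a gap beyond the scatter. Compound 1 and compound 2 differ in more than one place, so the two values show only that an ester of the one kind with a bare phenyl ring sits higher than an ester of the other kind with a hydroxyl on the ring.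

Compound 3 `COC(=O)C1=C(C)NC(=O)NC1c1ccc([N+](=O)[O-])cc1` is not yet measured in this assay. It derives from compound 2 by one change: nitro in place of hydrogen on an aromatic carbon

Within the data shown here, no step of this exact kind is available among the measured compounds. A step of modest size is expected, either direction possible, most likely within or just beyond the scatter. For compound 3 the estimated value in this assay is 1.6 ug/mL with a range of 0.6 ug/mL to 4.5 ug/mL, which means an expected step of a 1.4-fold lower number from compound 2 to compound 3 (0.14 log units; within the scatter).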

Compound 3, half-maximal effective concentration: 1.71 ug/mL
Compound 3: middle estimate off by 1.1-fold (0.03 log units), on the low side, within the range that was stated.
By their numbers in this assay, from the lowest: compounds 1, 3 and 2 (each within the scatter of the next, the first and the last beyond it).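

In this assay, nitro in place of hydrogen on an aromatic carbon, para to a large group, comes with a 1.3-fold lower number from compound 2 to compound 3 (0.12 log units; within the scatter). Among these compounds, this is the first comparison that differs in one place only, and it shows that this position can carry nitro, a group with no ring and no net charge, with a read-out not separable from that of the bare phenyl ring of compound 2. No measurement at hand bears on what lies behind this result.

As far as these compounds go, whether an amine or a carboxylic acid in the same place would give a step beyond the scatter remains open. From the compounds shown here alone, the hydroxyl of compound 1 sits on a different ester, so the separate contributions of the ester and the ring group also remain open.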